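The compounds below may be only part of what the source reports. "The series", "measured", "known", "first", "only" and "open" are said of these compounds alone.

Measured compounds:
Compound 1, `CC(C)COC(=O)c1cc(N2C(=O)C3=C(CCCC3)C2=O)c(F)cc1Cl`, in a functional assay on the whole organism for inhibition, with Scenedesmus acutus as the target (a higher number here means a weaker inhibitor, a lower number a stronger inhibitor), compound 1 gives 100 nM.
Compound 2, `CC(C)COC(=O)c1cc(N2C(=O)C3=C(CCCC3)C2=O)ccc1Cl`, in this assay compound 2 gives 977 nM.
Compound 3, `C#CCOc1cc(N2C(=O)C3=C(CCCC3)C2=O)ccc1Cl`, in this assay compound 3 gives 100 nM.

Compound 1 and compound 3 stand level in this assay at the digits shown, and together they are the lowest of the three numbers; compound 2 is the one that lies apart. Compound 3 differs from compound 2 in propargyloxy in place of isobutoxycarbonyl on an aromatic carbon, and that change gave a 9.8-fold lower number from compound 2 to compound 3 (0.99 log units; beyond the scatter). Compound 1 differs from compound 2 in fluoro in place of hydrogen on an aromatic carbon, and that change gave a 9.8-fold lower number from compound 2 to compound 1 (0.99 log units; beyond the scatter).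

The unmeasured compound 4, `C#CCOc1cc(N2C(=O)C3=C(CCCC3)C2=O)c(F)cc1Cl`, differs from compound 3 in fluoro in place of hydrogen on an aromatic carbon. This is the same kind of change as the one from compound 2 to compound 1, and it occurs twice among these compounds, but the surroundings are not identical: in compound 1 the entering fluoro sits para to an isobutoxycarbonyl group (7 heavy atoms), whereas in compound 4 it sits para to a propargyloxy group (4 heavy atoms). For the measured compounds named here, only one measured example of this change exists, so how far it carries over to the core of compound 3 is unknown.

Going by the values given here, compound 4 is expected to show a 4.0-fold lower number from compound 3 to compound 4 (0.60 log units; beyond the scatter) in this assay, a smaller step than the earlier one, because compound 3 already stands at 100 nM and the single precedent is a 9.8-fold lower number from compound 2 to compound 1 (0.99 log units; beyond the scatter). Compound 4 is estimated at 25 nM, with a likely range from 8 nM to 80 nM.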

Compound 4, half-maximal inhibitory concentration: 15.9 nM
The estimate for compound 4 lay 1.6-fold (0.20 log units) above the measured number, and the stated range covers the measured number.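

In this assay, for the compounds shown here, fluoro in place of hydrogen on an aromatic carbon also lowered the number on the core of compound 3, giving a 6.3-fold lower number from compound 3 to compound 4 (0.80 log units; beyond the scatter), and this step cannot be told apart from the earlier one on the core of compound 2: the same change on two cores in this assay, a 9.8-fold lower number (0.99 log units; beyond the scatter) from compound 2 to compound 1 and a 6.3-fold lower number (0.80 log units; beyond the scatter) from compound 3 to compound 4, 1.6-fold (0.19 log units) apart, within the scatter of two such steps The other change behaved in the same way, with propargyloxy in place of isobutoxycarbonyl giving a 6.3-fold lower number from compound 1 to compound 4 (0.80 log units; beyond the scatter) on the fluoro-bearing core, again matching its earlier step on the core without fluoro: the same change on two cores in this assay, a 9.8-fold lower number (0.99 log units; beyond the scatter) from compound 2 to compound 3 and a 6.3-fold lower number (0.80 log units; beyond the scatter) from compound 1 to compound 4, 1.6-fold (0.19 log units) apart, within the scatter of two such steps Across these four compounds, each change therefore carried over from one core to the other with little loss in size, but this rests on only one pair of steps for each change, so it does not show that either step would hold on a core that differs in any other place, and it gives no reason why the number falls.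

The compounds shown leave open whether a bromo or a methyl group on the same aromatic carbon would give a step of similar size to fluoro. They also leave open how a longer alkynyl ether chain or a carboxylic acid in place of propargyloxy would read on the core of compound 4.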